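Ester to amide at the carbonyl carbon

The compounds below may be only part of what the source reports. "The series", "measured", "known", "first", "only" and "open" are said of these compounds alone.

Measured compounds:
compound 1 `CCCOC(=O)/C=C(C)/C=C/CC(C)CCCC(C)C`, 7.28
compound 2 `CCCOC(=O)/C=C(C)/C=C/CC(C)CCCC(C)(C)OC`, 6.08
compound 3 `COC(C)(C)CCCC(C)C/C=C/C(C)=C/C(=O)OCCC(C)C`, 7.03

In a physicochemical assay for lipophilicity (on this read-out lower numbers stand for lower lipophilicity and higher numbers for higher lipophilicity), compound 1 gives the highest of the three numbers; compound 3 sits within the scatter of it, while compound 2 lies well below. The two measured steps, a number 1.20 log units lower from compound 1 to compound 2 (beyond the scatter) and a number 0.95 log units higher from compound 2 to compound 3 (beyond the scatter), both change the saturated chain and leave the carbonyl end untouched. Compound 4 `CC(/C=C/CC(C)CCCC(C)C)=C\C(=O)NCC(C)C` differs from compound 1 as follows: isobutylamino in place of propoxy on a carbonyl carbon. Going by the values given here, no measured step concerns this part of the molecule, so the expectation rests on the direction such swaps usually take, with the larger carbon chain of isobutylamino pulling the other way. A moderate decrease is expected, a number 0.78 log units lower from compound 1 to compound 4 (beyond the scatter), giving an estimated 6.5 for compound 4, within a range from 5.9 to 7.1.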

Compound 4, partition coefficient: 6.19
For compound 4 the middle estimate is 0.31 log units above the measured one; low and high end bracket the measured number.
By their numbers in this assay, from the lowest: compounds 2 and 4 (each within the scatter of the next); then compounds 3 and 1 (each within the scatter of the next).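

The carbonyl end of the molecule also matters in this assay, not only the saturated chain: isobutylamino in place of propoxy on a carbonyl carbon gives a number 1.09 log units lower from compound 1 to compound 4 (beyond the scatter), despite the larger carbon chain. The change also swaps a hydrogen-bond acceptor for a hydrogen-bond donor. No measurement here explains this drop.

Propylamino, which keeps the propyl chain, would show what the exchange of oxygen for nitrogen does alone. Dimethylamino, which has no amide hydrogen, leaves open whether that hydrogen matters.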